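Working notes: from compound 2 to compound 3

A few compounds are considered here, and "the series" means these few. Any claim that something is new, unique, unknown or untested is made for them only; others in the source may bear on it.

In a functional assay on A549 cells (Homo sapiens) for antiproliferative activity, with a stated time of 5 days (a higher number here means a weaker inhibitor, a lower number a stronger inhibitor), compound 2 `O=C1C=CC2(C=C1)OCC(=O)N2c1nc(-c2ccc3c(c2)OCCO3)nn1-c1ccccc1` gives 170 nM and compound 1 `CC1CN(c2nc(-c3ccc4ccccc4c3)nn2-c2ccccc2)C2(C=CC(=O)C=C2)O1` gives 320 nM so the two stand within the scatter of each other. Compound 3 `O=C1C=CC2(C=C1)OCC(=O)N2c1nc(-c2ccc3ccccc3c2)nn1-c1ccccc1` differs from compound 2 by naphthalen-2-yl in place of 2,3-dihydro-1,4-benzodioxin-6-yl on an aromatic carbon with naphthalen-2-yl in place of 2,3-dihydro-1,4-benzodioxin-6-yl on an aromatic carbon. Naphthalen-2-yl already stands in compound 1 at 320 nM in this assay so no large shift is expected. The expected step of a 1.3-fold higher number from compound 2 to compound 3 (0.11 log units; within the scatter) is small, within the scatter, and leans toward a higher number. For compound 3 the estimate is 220 nM in this assay with an expected range from 80 nM to 600 nM for a single measurement.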

Compound 3, half-maximal inhibitory concentration: 140 nM
Beside the measured number, compound 3's estimate is 1.6-fold (0.20 log units) above it, within the range that was stated.
By their numbers in this assay, from the lowest: compounds 3, 2 and 1 (each within the scatter of the next, the first and the last beyond it).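

In this assay, the aromatic carbon between two ring nitrogen atoms accepts naphthalen-2-yl in place of 2,3-dihydro-1,4-benzodioxin-6-yl with a 1.2-fold lower number from compound 2 to compound 3 (0.08 log units; within the scatter). At this position, then, the all-carbon bicycle and the ring with 2 hetero atoms stand level, so the 2 hydrogen-bond acceptors of the leaving group show no measurable call on them here. No measured evidence bears on this result.

Open, on these data alone, is whether a smaller group at this carbon, such as methyl, holds the level. As far as these compounds go, an amine or a carboxylic acid on the naphthalen-2-yl also remains open.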